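The source may hold more compounds than are shown below. What is called first, only, known or untested is meant among the compounds shown, and "the series" means these compounds.

Measured compounds in a functional assay on HeLa cells (Homo sapiens) for antiproliferative activity, read by MTT assay, with a stated time of 72 h; a lower number here means a stronger inhibitor, a higher number a weaker inhibitor:
compound 1 `CC(=O)OCC(CCn1cc(C#Cc2ccc(Br)cc2)c(=O)n(C(=O)c2ccccc2)c1=O)COC(C)=O` — 47200 nM
compound 2 `CCCCCc1ccc(C#Cc2cn(CCC(COC(C)=O)COC(C)=O)c(=O)n(C(=O)c3ccccc3)c2=O)cc1` — 79100 nM

Compound 1 and compound 2 share the same core and differ only in the group on the aromatic carbon; the step of a 1.7-fold higher number from compound 1 to compound 2 (0.22 log units; within the scatter) does not separate them beyond the scatter, so compound 1 cannot be called stronger or weaker than compound 2 on these two numbers.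

Compound 3 `CC(=O)OCC(CCn1cc(C#CC2CC2)c(=O)n(C(=O)c2ccccc2)c1=O)COC(C)=O` is not yet measured. Against compound 1 the change is cyclopropyl in place of 4-bromophenyl on a triple-bonded carbon. Going by the values given here, the one measured step only exchanges a substituent on the aromatic ring that is now removed, so it gives no direction for this change, and nothing here points to a step beyond the scatter in either sense. The working expectation keeps compound 3 near compound 1. For compound 3 the estimated value in this assay is 60000 nM, range 20000 nM to 200000 nM, an expected step of a 1.3-fold higher number from compound 1 to compound 3 (0.10 log units; within the scatter).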

Compound 3, half-maximal inhibitory concentration: > 100000 nM
Compound 3: no number, only a limit (the forecaster's own chance of this, stated with the estimate: 20%); middle value at least 1.6-fold (0.22 log units) away from the limit.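

In this assay compound 3 gives only a limit, > 100000 nM and not a number. Exchange at the triple-bonded carbon itself, unlike the earlier substituent exchange on the aromatic ring, gives a readable loss of activity, with an at least 2.1-fold higher number from compound 1 to compound 3 (0.32 log units; beyond the scatter) for cyclopropyl in place of 4-bromophenyl. The comparison with the pentyl-bearing compound is less firm: an at least 1.2-fold higher number from compound 2 to compound 3 (0.10 log units; that floor lies within the scatter) gives only a floor and sets no order between these two compounds.

The compounds shown do not tell whether the loss follows the removal of the aromatic ring or the entry of the cyclopropyl ring, a question that an unsubstituted phenyl or a butyl chain on the triple-bonded carbon could address. Going by these compounds, how an amine or a carboxylic acid on the aromatic ring would read in this assay also stays open.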